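The source may hold more compounds than are shown below. What is called first, only, known or untested is meant among the compounds shown, and "the series" means these compounds.

Compound 1, with the structure `COc1cc(OC)c(C(=O)/C=C/c2ccc(Br)cc2)c(OC)c1`, was tested in a functional assay on Caco-2 cells (Homo sapiens), read by fluorescence and BrdU incorporation, with a stated time of 48 h, tested at 25 uM (on this read-out higher numbers stand for a weaker effect at the one concentration tested and lower numbers for a stronger effect), and gave 1.9%. That is the lowest of the two values at hand, and on this read-out a lower number means a stronger effect at the single concentration used. Among the measured compounds shown here, the only other measured member of the set, compound 2, with the structure `COc1cc(O)c(C(=O)/C=C/c2ccccc2SC)c(OC)c1`, gave 37% in the same assay, a number that lies beyond the usual scatter above the value of compound 1. Compound 2 differs from compound 1 in several places at once, so no single-change step can be read from that pair.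

Compound 3, with the structure `COc1cc(OC)c(C(=O)/C=C/c2ccc(F)cc2)c(OC)c1`, has not yet been measured. Its difference from compound 1 is a single one: fluoro in place of bromo on an aromatic carbon. For the measured compounds named here, no measured pair shows what this exchange does here. The expectation in this assay is a step of modest size toward a higher number, that is a somewhat weaker effect, which could still fall within the scatter. The estimated step of a number 10.1 percentage points higher from compound 1 to compound 3 (beyond the scatter) starts from compound 1 giving 1.9%. For compound 3 the expected value is 12%, with a range from 2% to 45%.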

Compound 3, a percentage reported as activity, at one concentration (the size of the read-out at that concentration, not a potency): 13%
Compound 3: the middle estimate sits 1 percentage points below what was measured; low and high end bracket the measured number.
By their numbers in this assay, from the lowest: compound 1; then compound 3; then compound 2.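

Among the compounds shown here, this is the first direct reading of a single change in the set: with the core of compound 1 held constant, fluoro in place of bromo on the aromatic carbon gives a number 11.1 percentage points higher from compound 1 to compound 3 (beyond the scatter) in this assay. The step is modest but lies beyond the usual scatter, so this place on the ring is sensitive to which halogen it carries, and in this pair the bromo compound shows the stronger effect at the one concentration tested. No measurement here accounts for the difference between the two halogens, so the step records what happens without explaining it.

A single pair cannot show how the read-out would respond to other groups at this place, such as chloro, methyl, methoxy, an amine or a carboxylic acid, so no trend across substituents can yet be drawn. From the compounds shown here alone, it also remains open whether the change from 4-bromophenyl to 4-fluorophenyl would give a step of similar size if the methoxy groups on the other ring were replaced, for example by a hydroxyl group.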